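From Chlorophenyl to Furan on a Shared Core

The source may hold more compounds than are shown below. What is called first, only, known or untested is meant among the compounds shown, and "the series" means these compounds.

Compound 1 `CCOC(=O)C12C(=O)OCC=C1COC2c1ccccc1` carries a plain phenyl group on the shared core, compound 2 `CCOC(=O)C12C(=O)OCC=C1COC2c1ccccc1F` carries a 2-fluorophenyl group, and compound 3 `CCOC(=O)C12C(=O)OCC=C1COC2c1ccc(Cl)cc1` a 4-chlorophenyl group. In a functional assay on QGY cells (Homo sapiens) for cytotoxicity, read by MTT assay (a higher number here means a weaker inhibitor, a lower number a stronger inhibitor), compound 1 reaches only the limit of the assay, > 1000000 nM. In this assay compound 2 likewise reaches only a limit, > 1000000 nM. In this assay compound 3 also gives only a limit, > 1000000 nM, so its standing is known only as a boundary and not as a number. The steps a step that the two limits leave unreadable from compound 1 to compound 2, a step that the two limits leave unreadable from compound 1 to compound 3 and a step that the two limits leave unreadable from compound 2 to compound 3 cannot be sized because of the limit of > 1000000 nM in this assay, at which 3 of the 3 values shown sit. Compound 4 `CCOC(=O)C12C(=O)OCC=C1COC2c1ccco1` differs from compound 3 by furan-2-yl in place of 4-chlorophenyl on a saturated ring carbon. Since every measured step is unreadable, no direction can be drawn from them, and the step of a number no higher from compound 3 to compound 4 (the limit leaves the size open) is therefore expected to stay within the usual scatter. Compound 4 is expected to give about 1000000 nM in this assay, within a range from 300000 nM to 3000000 nM, and most likely to be reported again only as a limit.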

Compound 4, half-maximal inhibitory concentration: > 1000000 nM
Compound 4: only a limit was reported (the forecaster's own chance of this, stated with the estimate: 85%); the middle value lies on the limit itself.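

The steps to compound 4 from compound 1, compound 2 and compound 3 cannot be read, because all these results are limits and not numbers: the limit of > 1000000 nM in this assay, at which 4 of the 4 values shown sit. From the compounds shown here alone, whether the phenyl, 2-fluorophenyl, 4-chlorophenyl and furan-2-yl groups differ at all in this assay stays open.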